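The source may hold more compounds than are shown below. What is called first, only, known or untested is meant among the compounds shown, and "the series" means these compounds.

Measured compounds:
compound 1 `N#Cc1ccc(NC(=O)NCc2cnc3scc(-c4ccc(Br)cc4)n23)cc1`: 97%
compound 2 `COc1ccc(C(=O)N(C)CC(=O)NCc2cnc3scc(-c4ccc(Br)cc4)n23)cc1`: 49%
compound 3 `COc1cccc(C(=O)N(C)CC(=O)NCc2cnc3scc(-c4ccc(Br)cc4)n23)c1`: 48%

In an assay on isolated protein for inhibition of Indoleamine 2,3-dioxygenase 1 (Homo sapiens), with a stated time of 60 min, tested at 1 uM (on this read-out higher numbers stand for more inhibition at the one concentration tested (going by the name of the read-out) and lower numbers for less inhibition), compound 1 gives 97%, the highest of the three numbers. Compound 2 gives 49% and compound 3 gives 48%, and both lie beyond the scatter below compound 1. For the measured compounds named here, the only measured step between compounds differing in one place is a number 1 percentage points lower from compound 2 to compound 3 (within the scatter), a swap of one methoxyphenyl for another that stays within the scatter.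

The unmeasured compound 4 `O=C(CO)NCc1cnc2scc(-c3ccc(Br)cc3)n12` differs from compound 1 in this way: hydroxymethyl in place of (4-cyanophenyl)amino on a carbonyl carbon. Going by the values given here, no measured step bears directly on removing the (4-cyanophenyl)amino group, since the one step concerns only the methoxyphenyl position. What the numbers do show is that compound 2 and compound 3, which carry something other than the (4-cyanophenyl)amino group on the carbonyl carbon, both lie beyond the scatter below compound 1. Replacing that group with the two-atom hydroxymethyl is therefore expected to lower inhibition beyond the scatter, likely more than seen for compound 2. The expected step is a number 72 percentage points lower from compound 1 to compound 4 (beyond the scatter). Compound 4 is estimated at 25%, with a range from 5% to 55%.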

Compound 4, a percentage reported as inhibition, at one concentration (the size of the read-out at that concentration, not a potency): 48%
Compound 4: middle estimate off by 23 percentage points, on the low side; measured number inside the range.
By their numbers in this assay, from the lowest: compounds 3, 4 and 2 (each within the scatter of the next); then compound 1.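

In this assay, hydroxymethyl in place of (4-cyanophenyl)amino on the carbonyl carbon gives a number 49 percentage points lower from compound 1 to compound 4 (beyond the scatter), which puts a direct size on this one change at this position. Inhibition does not vanish with the smaller group: compound 4 gives 48%, and that number lies within the scatter of compound 2 at 49% and compound 3 at 48%, so among these three the very different groups on the carbonyl carbon give no separable numbers. The data shown offer no measured explanation for the large step from the (4-cyanophenyl)amino group to hydroxymethyl.

As far as these compounds go, what remains open is which part of the (4-cyanophenyl)amino group goes with the high number, since its nitrile, its aromatic ring and its amino nitrogen all leave together in this one step. A plain phenylamino group without the nitrile would separate the nitrile from the ring, and an aminomethyl group in place of hydroxymethyl would show whether the number at this small size changes with the atom at the end of the chain.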